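Swapping Chloro for Vinyl: Expected Potency of Compound 4

The source may hold more compounds than are shown below. What is called first, only, known or untested is meant among the compounds shown, and "the series" means these compounds.

Compound 1 `CCCCCCCCC(=O)NCc1cc(I)c(O)c(OC)c1` gives 126 nM in an assay on HEK293 cells for inhibition of transient receptor potential cation channel subfamily V member 1 (Homo sapiens); on this read-out lower numbers stand for stronger inhibition and higher numbers for weaker inhibition.
Compound 2 `CCCCCCCCC(=O)NCc1cc(Br)c(O)c(OC)c1` gives 252 nM in this assay.
Compound 3 `CCCCCCCCC(=O)NCc1cc(Cl)c(O)c(OC)c1` gives 631 nM in this assay.

Compound 3 has the highest number of the three: a 2.5-fold higher number from compound 2 to compound 3 (0.40 log units; beyond the scatter) and a 5.0-fold higher number from compound 1 to compound 3 (0.70 log units; beyond the scatter), while compound 1 and compound 2 lie within the scatter of each other, a 2.0-fold higher number from compound 1 to compound 2 (0.30 log units; within the scatter). Compound 4 `C=Cc1cc(CNC(=O)CCCCCCCC)cc(OC)c1O` differs from compound 3 in one place: vinyl in place of chloro on an aromatic carbon. Among the measured compounds shown here, no measured step exchanges a halogen for a carbon group, so the halogen steps only show that a change on this aromatic carbon can shift the number modestly. A modest step in either direction is therefore expected, and in this assay compound 4 is estimated at 400 nM, between 150 nM and 1200 nM, which means a 1.6-fold lower number from compound 3 to compound 4 (0.20 log units; within the scatter).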

Compound 4, half-maximal inhibitory concentration: 390 nM
The estimate for compound 4 lay 1.0-fold (0.01 log units) above the measured number; measured number inside the range.
By their numbers in this assay, from the lowest: compounds 1, 2, 4 and 3 (each within the scatter of the next, the first and the last beyond it).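

A carbon group can take the place of a halogen on this aromatic carbon, ortho to a hydroxy group, and the number in this assay stays within the scatter of two halogen compounds: vinyl for chloro gives (a 1.6-fold lower number from compound 3 to compound 4 (0.21 log units; within the scatter)) and vinyl for bromo gives (a 1.5-fold higher number from compound 2 to compound 4 (0.19 log units; within the scatter)). Only iodo stands clearly apart from vinyl (a 3.1-fold higher number from compound 1 to compound 4 (0.49 log units; beyond the scatter)). No measurement shown here explains these steps. With vinyl the only carbon group shown, one compound cannot tell how other carbon groups behave here. From the compounds shown here alone, how an ethyl group, an amine or a carboxylic acid on this carbon would compare remains open.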